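Swapping hydroxy for acetamido: an acid dissociation estimate

The compounds below may be only part of what the source reports. "The series", "measured", "known", "first", "only" and "open" are said of these compounds alone.

Measured compounds:
- compound 1, `CC(=O)Nc1ccc(OC(=S)Nc2ccc(Nc3ccc([N+](=O)[O-])cc3)cc2)cc1`: 9.04
- compound 2, `CC(=O)Nc1ccc(OC(=S)Nc2ccc(Nc3ccc(C(F)(F)F)cc3)cc2)cc1`: 9.05
- compound 3, `Oc1ccc(OC(=S)Nc2ccc(Nc3ccc(C(Cl)(Cl)Cl)cc3)cc2)cc1`: 9.23

In a physicochemical assay for acid dissociation, compound 3 gives the highest of the three numbers, yet its gap to compound 2 and to compound 1 is within the scatter. Compound 4, `CC(=O)Nc1ccc(OC(=S)Nc2ccc(Nc3ccc(C(Cl)(Cl)Cl)cc3)cc2)cc1`, differs from compound 3 by acetamido in place of hydroxy on an aromatic carbon. Among the measured compounds shown here, no measured step covers this exchange; the only step known, a number 0.01 log units higher from compound 1 to compound 2 (within the scatter), concerns a different position and was within the scatter. Compounds 1 and 2 already carry acetamido and their values sit close to compound 3, so no step beyond the scatter is expected, a number 0.15 log units lower from compound 3 to compound 4 (within the scatter). Compound 4 is estimated at 9.08, between 8.8 and 9.35.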

Compound 4, acid dissociation constant: 9.01
For compound 4 the middle estimate is 0.07 log units above the measured one, and the stated range covers the measured number.
By their numbers in this assay, from the lowest: compounds 4, 1, 2 and 3 (each within the scatter of the next).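

In this assay, acetamido in place of hydroxy on this aromatic carbon gives a number 0.22 log units lower from compound 3 to compound 4 (within the scatter), so this first look at the exchange shows no difference beyond the scatter between 4-hydroxyphenyl and 4-acetamidophenyl. Trichloromethyl, now seen with acetamido in place, also stays within the scatter of the other two groups at the far end of the molecule, with a number 0.04 log units lower from compound 2 to compound 4 (within the scatter) and a number 0.03 log units lower from compound 1 to compound 4 (within the scatter).

From the compounds shown here alone, whether an amine or a carboxylic acid on this aromatic carbon would move the number beyond the scatter remains open. Nothing available explains why these values stay so close.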